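A few compounds are considered here, and "the series" means these few. Any claim that something is new, unique, unknown or untested is made for them only; others in the source may bear on it.

Compound 1 `O=c1sc2cc(NS(=O)(=O)c3ccccc3)ccc2n1CCN1CCCC1`: 11% in an assay on HEK293 cells for displacement of a labelled ligand from 5-hydroxytryptamine receptor 6 (Homo sapiens), read by radioligand binding, with a stated time of 60 min, tested at 100 nM; on this read-out higher numbers stand for more inhibition at the one concentration tested (going by the name of the read-out) and lower numbers for less inhibition
Compound 2 `CN(C)CCn1c(=O)sc2cc(NS(=O)(=O)c3ccc4ccccc4c3)ccc21`: 22% in this assay

Of these two numbers compound 2 holds the higher one, and its gap to compound 1 lies beyond the usual scatter. The two compounds differ in more than one place, so no single exchange can be read from them. Compound 3 `O=c1sc2cc(NS(=O)(=O)c3ccc4ccccc4c3)ccc2n1CCN1CCCC1` keeps everything of compound 2 except (pyrrolidin-1-yl in place of dimethylamino on a saturated chain carbon, two bonds along the chain from an aromatic nitrogen). Within the data shown here, no measured pair shows what this exchange does, so the step in this assay is expected to be small, in no settled direction, and probably within the scatter. For compound 3 the expected value is 23%, with a range from 8% to 40%. This amounts to an expected step of a number 1 percentage points higher from compound 2 to compound 3 (within the scatter).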

Compound 3, a percentage reported as inhibition, at one concentration (the size of the read-out at that concentration, not a potency): 0%
Compound 3: middle estimate off by 23 percentage points, on the high side; measured number below the stated range.
By their numbers in this assay, from the lowest: compound 3; then compound 1; then compound 2.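

Exchanging dimethylamino for pyrrolidin-1-yl on the chain is not a neutral swap in this assay: it gives a number 22 percentage points lower from compound 2 to compound 3 (beyond the scatter), so the amine at this position affects the reading. With pyrrolidin-1-yl held fixed, naphthalen-2-yl in place of phenyl on the sulfonyl sulfur gives a number 11 percentage points lower from compound 1 to compound 3 (beyond the scatter), so the change brings no gain alongside this amine. Nothing measured here gives a reason for either step.

On these data alone, whether naphthalen-2-yl has the same effect alongside dimethylamino stays open. So does how a piperidine ring or a longer chain at the amine end would read.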